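The compounds below may be only part of what the source reports. "The series", "measured", "known", "first", "only" and "open" are said of these compounds alone.

Compound 2, `CC(O)CC#Cc1c(Cl)c2c(Cl)cc(C(N)=O)nc2n1[C@H]1CCCNC1`, is the starting point of this step. Among the compounds with values here, in a physicochemical assay for solubility, measured as thermodynamic solubility, at pH 7.4 (on this read-out lower numbers stand for lower solubility and higher numbers for higher solubility), compound 2 gives 760000 nM, the only number it has there, alongside one further entry that came back without a single number. Compound 1, `NC(=O)c1cc(Cl)c2c(Cl)c(C#CC3CCCO3)n([C@H]3CCCNC3)c2n1`, shares the core and has been measured more than once in this assay; compound 1 gives 207000 nM; 333000 nM (2 entries), and the several entries of compound 1 in this assay, 207000 nM; 333000 nM (2 entries) shows how closely its repeats agree. Within the data shown here, no pair of measured compounds differing in one place is available, so no measured step can be pointed to.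

Compound 3, `COCCC#Cc1c(Cl)c2c(Cl)cc(C(N)=O)nc2n1[C@H]1CCCNC1`, is the compound still to be measured. It differs from compound 2 as follows: methoxymethyl in place of 1-hydroxyethyl on a saturated chain carbon bound to a triple-bonded carbon. The change is small and keeps the same atoms; what departs is a group with a hydrogen-bond donor, and what arrives has none.

Among the measured compounds shown here, with no measured step of this kind to lean on, a modest move in this assay is expected, if anything toward lower solubility, and it may well stay within the usual scatter. Compound 3 is therefore expected to give 450000 nM, in a range from 150000 nM to 1200000 nM, which corresponds to an expected step of a 1.7-fold lower number from compound 2 to compound 3 (0.23 log units; within the scatter).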

Compound 3, solubility: 86000 nM
For compound 3 the middle estimate is 5.2-fold (0.72 log units) above the measured one; the whole stated range lies above it.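

The change of 1-hydroxyethyl to methoxymethyl, on a saturated chain carbon bound to a triple-bonded carbon, keeps the same atoms, yet in this assay it gives an 8.8-fold lower number from compound 2 to compound 3 (0.95 log units; beyond the scatter). Within the data shown here, this is the first measured step at this place, and it shows that the read-out responds to how these atoms are joined, even though the group count falls only from 1 hydrogen-bond donor to 0 and the hydrogen-bond acceptor count stays at 1. The step also stands out against the spread of repeated measurements on a single compound, so it is unlikely to be a matter of repeat noise alone: the several entries of compound 1 in this assay, 207000 nM; 333000 nM (2 entries)

Because this single step changes the donor count and the position of the oxygen together, the compounds shown cannot say which of the two matters, or whether either does on its own. From the compounds shown here alone, how this assay would respond to an amine or a carboxylic acid at this place, or to a longer chain ending in a methoxy group, also remains open.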